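The source may report more compounds than this note shows. Statements on the series, on what has been measured and on what is new or still open speak of the compounds shown alone.

Of the compounds shown here, three sharing one core have been measured in an ADME assay on L6 cells (Rattus norvegicus) for cytotoxicity, read by resazurin assay; a higher number here means a weaker inhibitor, a lower number a stronger inhibitor. Compound 1, `N=C(N)c1ccc2[nH]c(-c3ccc4nc(-c5ccc(F)cc5)[nH]c4c3)nc2c1`, gives 2.48 ug/mL. Compound 2, `CC(C)(C)c1ccc(-c2nc3ccc(-c4nc5cc(C(=N)N)ccc5[nH]4)cc3[nH]2)cc1`, gives 13 ug/mL. Compound 3, `COc1cc(OC)cc(-c2nc3ccc(-c4nc5cc(C(=N)N)ccc5[nH]4)cc3[nH]2)c1`, gives 25.5 ug/mL. Among these numbers compound 2 stands second highest: the step of a 2.0-fold higher number from compound 2 to compound 3 (0.29 log units; within the scatter) is within the scatter, while the step of a 5.2-fold higher number from compound 1 to compound 2 (0.72 log units; beyond the scatter) is beyond it, so compound 2 is separated only from compound 1.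

Compound 4, `N=C(N)c1ccc2[nH]c(-c3ccc4nc(-c5ccc(OCc6ccccc6)cc5)[nH]c4c3)nc2c1`, is the next compound to consider. It differs from compound 2 in one place: benzyloxy in place of tert-butyl on an aromatic carbon.

Among the measured compounds shown here, two measured steps touch this position. The step of a 5.2-fold higher number from compound 1 to compound 2 (0.72 log units; beyond the scatter) shows that exchanging a small group for a larger one at this carbon raised the number clearly. The step of a 10-fold higher number from compound 1 to compound 3 (1.01 log units; beyond the scatter) was larger still, but the change there was on the whole phenyl, and the step of a 2.0-fold higher number from compound 2 to compound 3 (0.29 log units; within the scatter) did not reach beyond the scatter. For the measured compounds named here, no measured step involves benzyloxy itself, so the direction for compound 4 is uncertain. The expectation for compound 4 is a number near that of compound 2, perhaps somewhat higher, giving an estimated step of a 1.2-fold higher number from compound 2 to compound 4 (0.06 log units; within the scatter). Compound 4 is therefore estimated at 15 ug/mL, with a range from 4 ug/mL to 45 ug/mL.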

Compound 4, half-maximal inhibitory concentration: 17.4 ug/mL
For compound 4 the middle estimate is 1.2-fold (0.06 log units) below the measured one, within the range that was stated.
By their numbers in this assay, from the lowest: compound 1; then compounds 2, 4 and 3 (each within the scatter of the next).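

In this assay the exchange of tert-butyl for benzyloxy, which brings in an oxygen and a second aromatic ring, gives a 1.3-fold higher number from compound 2 to compound 4 (0.13 log units; within the scatter) and so does not separate these two quite different groups at this carbon. Among the compounds shown here, measured against the fluoro group, benzyloxy gives a 7.0-fold higher number from compound 1 to compound 4 (0.85 log units; beyond the scatter) and thus also stands clearly apart from the small group, so compound 1 remains the only compound separated from the others with a lower number, meaning the stronger inhibitor of the cells. Nothing available explains why fluoro differs from the two larger groups or why those two read alike.

The compounds shown leave open whether the low number of compound 1 belongs to fluoro in particular or would also appear with another small group such as chloro or methyl. They also leave open how an amine, a carboxylic acid or a longer alkyl chain would read at this same carbon, which would test whether the similarity of compound 2 and compound 4 extends to other kinds of group.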